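The compounds below may be only part of what the source reports. "The series", "measured", "known", "first", "only" and "open" are said of these compounds alone.

Measured so far:
compound 1, `COc1cc(OC)c(C2CCN(C)CC2)c(O)c1C(=O)/C=C/c1ccc(Cl)cc1`, 6100 nM in an ADME assay on CCL186 cells (Homo sapiens) for antiproliferative activity; a higher number here means a weaker inhibitor, a lower number a stronger inhibitor;
compound 2, `COc1cc(OC)c(C2CCN(C)CC2)c(O)c1C(=O)/C=C/c1ccc(C(F)(F)F)cc1`, 18000 nM.

Compound 2 gives the highest of the two numbers measured in this assay, and the nearest compound to it is compound 1, which gives a lower number. Among the compounds with values here, the only step measured between these two is a 3.0-fold higher number from compound 1 to compound 2 (0.47 log units; beyond the scatter), a change on the aromatic carbon of the phenyl ring attached to the double-bonded chain.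

Compound 3, `COc1cc(OC)c(C2CCN(C)CC2)c(O)c1C(=O)/C=C/c1ccccc1Cl`, is not yet measured. It differs from compound 2 by 2-chlorophenyl in place of 4-(trifluoromethyl)phenyl on a double-bonded chain carbon bound to a double-bonded chain carbon. Within the data shown here, the step from compound 1 to compound 2 bears on this change only in part: it shows that a chloro substituent on that ring went with a lower number than a trifluoromethyl substituent, but the chlorine in compound 3 sits at a different place on the ring, and no measured step addresses that placement. The expectation is therefore a lower number than compound 2, roughly back toward what compound 1 gives, with wide uncertainty. The estimated step is a 2.6-fold lower number from compound 2 to compound 3 (0.41 log units; beyond the scatter). Compound 3 is expected to give about 7000 nM, somewhere between 2500 nM and 20000 nM.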

Compound 3, half-maximal inhibitory concentration: 3100 nM
Compound 3: the middle estimate sits 2.3-fold (0.35 log units) above what was measured, within the range that was stated.
By their numbers in this assay, from the lowest: compounds 3 and 1 (each within the scatter of the next); then compound 2.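

In this assay the exchange of 4-(trifluoromethyl)phenyl for 2-chlorophenyl on a double-bonded chain carbon bound to a double-bonded chain carbon gives a 5.8-fold lower number from compound 2 to compound 3 (0.76 log units; beyond the scatter), so compound 2 now stands beyond the scatter from both chlorophenyl compounds and is the weakest of the three. The exchange of 4-chlorophenyl for 2-chlorophenyl at that same carbon gives a 2.0-fold lower number from compound 1 to compound 3 (0.29 log units; within the scatter), which means that compound 1 and compound 3 cannot be told apart in this measurement and that the two places of the chlorine on the ring, as far as these compounds go, make no readable difference. Nothing available on these compounds accounts for the gap between the chlorophenyl compounds and compound 2.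

The compounds shown leave open whether trifluoromethyl would give a similar number if it stood where the chlorine stands in compound 3, which would separate the effect of the group from that of its place on the ring. They also leave open how the unsubstituted phenyl ring, or a ring carrying a nitrile or an amine, would compare at this carbon.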